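This account rests on a few compounds, and the source may have more. Where it says the series, first, only, none or still open, it means among the compounds named here.

Compound 1 `N#CCCCc1c[nH]c2ccc(F)cc12` gives 63 nM in an assay on isolated protein (urine) for inhibition of Myeloperoxidase (Homo sapiens), with a stated time of 5 min; on this read-out lower numbers stand for stronger inhibition and higher numbers for weaker inhibition.
Compound 2 `CNC(=O)CCCc1c[nH]c2ccc(F)cc12` gives 40 nM in this assay.
Compound 3 `N#CSCCCc1c[nH]c2ccc(F)cc12` gives 5 nM in this assay.

Among these three, compound 1 shows the highest number; compound 2 lies nearest to it a 1.6-fold lower number from compound 1 to compound 2 (0.20 log units; within the scatter) and compound 3 furthest a 13-fold lower number from compound 1 to compound 3 (1.10 log units; beyond the scatter). Compound 4 `ONCCCc1c[nH]c2ccc(F)cc12` differs from compound 1 in one place: hydroxyamino in place of cyano on a saturated chain carbon, three bonds along the chain from an aromatic carbon. Among the compounds with values here, no measured step involves hydroxyamino itself. The two steps from compound 1 point in the same direction but differ in size: a 1.6-fold lower number from compound 1 to compound 2 (0.20 log units; within the scatter) against a 13-fold lower number from compound 1 to compound 3 (1.10 log units; beyond the scatter). A change at this same chain carbon has therefore ranged from negligible to large, and a lower number than compound 1 is the more likely outcome, with its size uncertain. Compound 4 is accordingly expected to give 20 nM (range 4 nM to 100 nM), meaning an expected step of a 3.2-fold lower number from compound 1 to compound 4 (0.50 log units; beyond the scatter).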

Compound 4, half-maximal inhibitory concentration: 11 nM
Compound 4: middle estimate off by 1.8-fold (0.26 log units), on the high side; measured number inside the range.
By their numbers in this assay, from the lowest: compound 3; then compound 4; then compounds 2 and 1 (each within the scatter of the next).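

At this chain carbon in this assay, a group with neither a triple bond nor a carbonyl still lowers the number: hydroxyamino brings a 5.7-fold lower number from compound 1 to compound 4 (0.76 log units; beyond the scatter) and a 3.6-fold lower number from compound 2 to compound 4 (0.56 log units; beyond the scatter). It does not reach cyanosulfanyl, though, with a 2.2-fold higher number from compound 3 to compound 4 (0.34 log units; beyond the scatter), so compound 3 keeps the lowest number of the four. Nothing available here accounts for these differences.

On these data alone, whether an amine or a carboxylic acid at this carbon would match compound 3 remains open. So does what a longer chain carrying hydroxyamino would give.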